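This account rests on a few compounds, and the source may have more. Where it says the series, first, only, none or still open, it means among the compounds named here.

In a functional assay on KB cells (Homo sapiens) for cytotoxicity (a lower number here means that less compound is needed, a higher number that more compound is needed for the effect), compound 2 `COC1=C(C)C(=O)/C(=C(O)/C=C/c2ccc(OC)cc2)C(=O)C1(C)C` gives 3.6 ug/mL. Among the three measured compounds this is the second highest number: compound 1 `COC1=C(C)C(=O)/C(=C(O)/C=C/c2ccc(Br)cc2)C(=O)C1(C)C` gives 1.7 ug/mL, so that a 2.1-fold higher number from compound 1 to compound 2 (0.33 log units; beyond the scatter), while compound 3 `COC1=C(C)C(=O)/C(=C(O)/C=C/c2ccccc2C)C(=O)C1(C)C` gives 4.1 ug/mL, and a 1.1-fold higher number from compound 2 to compound 3 (0.06 log units; within the scatter). Compound 4 `COC1=C(C)C(=O)/C(=C(O)/C=C/c2ccco2)C(=O)C1(C)C` changes the aromatic group at the end of the chain: furan-2-yl in place of 4-methoxyphenyl on a double-bonded chain carbon bound to a double-bonded chain carbon. Two measured steps also swap that aromatic group, a 2.4-fold higher number from compound 1 to compound 3 (0.38 log units; beyond the scatter) and a 1.1-fold higher number from compound 2 to compound 3 (0.06 log units; within the scatter), and both are modest or within the scatter. Nothing measured here carries a five-membered ring, so compound 4 is expected to give a 1.3-fold higher number from compound 2 to compound 4 (0.10 log units; within the scatter), most likely not beyond the scatter. The estimate for compound 4 is 4.5 ug/mL, with a range from 2 ug/mL to 10 ug/mL.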

Compound 4, concentration for half-maximal effect: 9.9 ug/mL
Beside the measured number, compound 4's estimate is 2.2-fold (0.34 log units) below it, and the stated range covers the measured number.
By their numbers in this assay, from the lowest: compound 1; then compounds 2 and 3 (each within the scatter of the next); then compound 4.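

Among the six-membered aromatic rings at this place on the chain, the numbers stayed within a narrower span, but the five-membered furan-2-yl ring goes further: a 2.8-fold higher number from compound 2 to compound 4 (0.44 log units; beyond the scatter) and a 2.4-fold higher number from compound 3 to compound 4 (0.38 log units; beyond the scatter) and a 5.8-fold higher number from compound 1 to compound 4 (0.77 log units; beyond the scatter) all point the same way. In this assay compound 4 therefore needs the most compound of the four, so this position does respond to the aromatic group, though each step remains modest.

On these data alone, whether the smaller ring or its oxygen matters more stays open, as does how a thiophene ring, with sulfur in the ring, would compare. No measurement at hand explains the steps.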